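Swapping a Trifluorophenyl for a Nitrophenyl on the Amine

The source may report more compounds than this note shows. Statements on the series, on what has been measured and on what is new or still open speak of the compounds shown alone.

Three compounds built on a shared core have been measured in a functional assay, with a stated time of 6 min; a higher number here means a weaker inhibitor, a lower number a stronger inhibitor:

Compound 1 `S=c1[nH]nc(-c2ccc3c(c2)OCCO3)o1` gives 10600 nM.
Compound 2 `Fc1cc(NCn2nc(-c3ccc4c(c3)OCCO4)oc2=S)cc(F)c1F` gives 2920 nM.
Compound 3 `FC(F)(F)c1ccccc1NCn1nc(-c2ccc3c(c2)OCCO3)oc1=S` gives 9220 nM.

Compound 2 stands at the lowest number of the three, so it is the strongest inhibitor here; its gaps to compound 3 and to compound 1 both lie beyond the usual scatter. Compound 4 `O=[N+]([O-])c1cccc(NCn2nc(-c3ccc4c(c3)OCCO4)oc2=S)c1` has not yet been measured. It differs from compound 2 in one place: 3-nitrophenyl in place of 3,4,5-trifluorophenyl on an amine nitrogen. For the measured compounds named here, no measured pair shows this exact change, so the size of the step cannot be read off directly. Because compound 3 gives 9220 nM with a different group in the same place, a group swap here can move the number noticeably, and a loss of potency is expected. The step expected is a 1.7-fold higher number from compound 2 to compound 4 (0.23 log units; within the scatter). Compound 4 is estimated at 5000 nM, within a range from 1500 nM to 15000 nM.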

Compound 4, half-maximal inhibitory concentration: 8870 nM
Beside the measured number, compound 4's estimate is 1.8-fold (0.25 log units) below it; measured number inside the range.
By their numbers in this assay, from the lowest: compound 2; then compounds 4, 3 and 1 (each within the scatter of the next).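

In this assay, for the compounds shown here, the change to 3-nitrophenyl in place of 3,4,5-trifluorophenyl on the amine nitrogen is a 3.0-fold higher number from compound 2 to compound 4 (0.48 log units; beyond the scatter) and gives the first direct one-place reading at this position. The two groups hold the same count of 9 heavy atoms and one six-membered aromatic ring each, so potency can drop with that count unchanged, while three fluorines leave and a nitrogen and two oxygens enter. Compound 4 at 8870 nM lies within the scatter of compound 3 at 9220 nM and compound 2 alone stands apart as the strongest inhibitor of the four.

Nothing shown here explains why the step occurs. On these data alone, whether a phenyl ring bearing a single fluorine, a methoxy group or a carboxylic acid would stay near compound 2 or fall back toward compound 4 remains open.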